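A few compounds are considered here, and "the series" means these few. Any claim that something is new, unique, unknown or untested is made for them only; others in the source may bear on it.

Working notes on the series. Compound 1 `NC(=O)c1c(NC(=O)c2ccccc2Cl)sc2c1CCN(Cc1ccc([N+](=O)[O-])cc1)C2`, compound 2 `NC(=O)c1c(NC(=O)c2ccccc2Cl)sc2c1CCN(Cc1cc(Cl)cc(Cl)c1)C2` and compound 3 `NC(=O)c1c(NC(=O)c2ccccc2Cl)sc2c1CCN(C(=O)Nc1ccccc1Cl)C2` share one core and differ only in the group carried on the amine nitrogen in the ring. In a functional assay on HL-60 cells (Homo sapiens) for antiproliferative activity, with a stated time of 24 h (on this read-out lower numbers stand for stronger inhibition and higher numbers for weaker inhibition), compound 1 gives 11400 nM. In this assay compound 2 gives 15800 nM. In this assay compound 3 gives 12500 nM. The three numbers sit close together: a 1.4-fold higher number from compound 1 to compound 2 (0.14 log units; within the scatter); a 1.1-fold higher number from compound 1 to compound 3 (0.04 log units; within the scatter); a 1.3-fold lower number from compound 2 to compound 3 (0.10 log units; within the scatter). Compound 3 thus stands second highest of the three, but neither its gap to compound 1 nor its gap to compound 2 goes beyond the scatter, so no order among them can be read.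

Compound 4 `NC(=O)c1c(NC(=O)c2ccccc2Cl)sc2c1CCN(C(=S)Nc1ccccc1I)C2` is the next member. Relative to compound 3 the change is a group of 10 heavy atoms (7 carbon, 1 nitrogen, 1 sulfur, 1 iodine; one six-membered aromatic ring of carbon only) in place of a group of 10 heavy atoms (7 carbon, 1 nitrogen, 1 oxygen, 1 chlorine; one six-membered aromatic ring of carbon only), on an amine nitrogen in a ring. Among the measured compounds shown here, no measured pair swaps the carbonyl of the carbamoyl for a thiocarbonyl, and none exchanges chlorine for iodine on the aromatic ring; the only steps that touch this position are the three exchanges of the whole group on the amine nitrogen, each of which stayed within the scatter. On that basis the expected step in this assay is none beyond the scatter, that is no change at the digits printed from compound 3 to compound 4 (within the scatter) as the working expectation. Compound 4 is therefore estimated at 12500 nM, with a range from 4500 nM to 35000 nM.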

Compound 4, half-maximal inhibitory concentration: 4430 nM
The estimate for compound 4 lay 2.8-fold (0.45 log units) above the measured number; the measured number lies below the stated range.
By their numbers in this assay, from the lowest: compound 4; then compounds 1, 3 and 2 (each within the scatter of the next).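

At the amine nitrogen in the ring, where the three earlier exchanges of the whole group stayed within the scatter, this assay now gives a step beyond it, with a 2.8-fold lower number from compound 3 to compound 4 (0.45 log units; beyond the scatter) for the group carrying sulfur and iodine in place of (2-chlorophenyl)carbamoyl. The same group also separates compound 4 from the two benzyl members, with a 3.6-fold lower number from compound 2 to compound 4 (0.55 log units; beyond the scatter) and a 2.6-fold lower number from compound 1 to compound 4 (0.41 log units; beyond the scatter) as further modest steps in the same direction, so this position can move the number, and compound 4 holds the lowest number of the four. The step from compound 3 swaps oxygen for sulfur and chlorine for iodine at once, so it cannot be assigned to either exchange, and nothing measured on these compounds accounts for it.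

Going by these compounds, whether a thiocarbonyl with the 2-chlorophenyl group, or a carbamoyl with iodine on the aromatic ring, would hold the lower number on its own remains open. Also open, on these data alone, is how the position responds to a group without an aromatic ring, such as acetyl or a longer alkyl chain, or to an amine or a carboxylic acid on the aromatic ring.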